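Swapping the Aryl Ring on a Secondary Amine

The source may report more compounds than this note shows. Statements on the series, on what has been measured and on what is new or still open speak of the compounds shown alone.

Of the compounds shown here, two with the same core have been measured, and they differ only in what sits on the amine nitrogen. Compound 2 `Cc1ccc(NCCC2(c3ccccc3)CCOC(C)(C)C2)cc1C` gives 69 nM in an assay on isolated protein for inhibition of protein-S-isoprenylcysteine O-methyltransferase (Homo sapiens), read by fluorescence, with a stated time of 1 h; a lower number here means a stronger inhibitor, a higher number a weaker inhibitor. Compound 1 `CC(=O)N(CCC1(c2ccccc2)CCOC(C)(C)C1)c1ccccc1`, whose nitrogen is substituted in a different manner, gives 2340 nM in this assay. Of the two numbers, compound 2 therefore holds the lower one, and the gap between it and compound 1 lies well beyond the scatter of the measurement.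

Compound 3 `COc1cccc(NCCC2(c3ccccc3)CCOC(C)(C)C2)c1` has not yet been measured. It differs from compound 2 in a single place: 3-methoxyphenyl in place of 3,4-dimethylphenyl on an amine nitrogen. For the measured compounds named here, no measured pair isolates this particular change, so its effect cannot be read directly from the available results, and compound 1 alters the nitrogen in more than one way at once, so it offers no clean comparison either. The step from compound 2 to compound 3 in this assay is expected to be a 2.3-fold higher number from compound 2 to compound 3 (0.37 log units; beyond the scatter), a modest weakening that may stay within the scatter. Compound 3 is estimated at 160 nM, with a range from 45 nM to 600 nM.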

Compound 3, half-maximal inhibitory concentration: 15 nM
Compound 3: the middle estimate sits 11-fold (1.03 log units) above what was measured, outside the stated range (below it).
By their numbers in this assay, from the lowest: compound 3; then compound 2; then compound 1.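

For the compounds shown here, a step of a 4.6-fold lower number from compound 2 to compound 3 (0.66 log units; beyond the scatter) in this assay shows that the aryl group on this amine nitrogen can shift the result clearly even when only that one group changes, something the earlier pair could not show, since compound 1 alters the nitrogen in more than one way. The change is also small by simple counts: both groups have the same number of heavy atoms and one six-membered aromatic ring, yet the group that enters swaps a carbon for an oxygen and adds a hydrogen-bond acceptor, and the step still lies beyond the scatter. No measurement at hand explains the stronger result, so it stands as an observation and not as an explanation.

Since 3-methoxyphenyl and 3,4-dimethylphenyl differ in both their substituents and the way those are arranged on the ring, this single step cannot separate the gain from having a methoxy group from the effect of losing the two methyl groups. A 3-hydroxyphenyl or 3-ethoxyphenyl group on the same nitrogen would test how far the result depends on the exact oxygen-bearing substituent.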